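Amide nitrogen substituent changed on the shared core

A few compounds are considered here, and "the series" means these few. Any claim that something is new, unique, unknown or untested is made for them only; others in the source may bear on it.

Going by the values given here, compound 3 `Cc1ccc(CNC(=O)c2[nH]cnc2C(=O)Nc2ccc(Cl)c(Cl)c2)cc1` gives 15200 nM in a functional assay on HL-60 cells (Homo sapiens), with a stated time of 4 days (on this read-out higher numbers stand for weaker inhibition and lower numbers for stronger inhibition), the highest of the three numbers measured so far. Compound 1 `O=C(NC1CCCCC1)c1nc[nH]c1C(=O)Nc1ccc(Cl)c(Cl)c1` gives 12300 nM in this assay, a value within the scatter of compound 3. Compound 2 `O=C(NCc1ccccc1)c1nc[nH]c1C(=O)Nc1ccc(Cl)c(Cl)c1` gives 7400 nM in this assay, and the gap from compound 3 to that value lies beyond the scatter. Among the compounds with values here, the single step between compounds differing in one place, a 1.7-fold lower number from compound 1 to compound 2 (0.22 log units; within the scatter), stays within the scatter.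

Compound 4 `C[C@@H](NC(=O)c1[nH]cnc1C(=O)Nc1ccc(Cl)c(Cl)c1)C(=O)OC(C)(C)C` differs from compound 3 by 1-(tert-butoxycarbonyl)ethyl in place of 4-methylbenzyl on an amide-type nitrogen. Within the data shown here, no measured step covers a group without a ring entering at this amide nitrogen; the one step available, a 1.7-fold lower number from compound 1 to compound 2 (0.22 log units; within the scatter), exchanged one ring-bearing group for another and was within the scatter, so it gives no direction. With nothing pointing either way, a step no larger than the scatter is expected, a 1.0-fold lower number from compound 3 to compound 4 (0.01 log units; within the scatter). For compound 4 the number in this assay is estimated at 15000 nM, with a range from 5000 nM to 50000 nM.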

Compound 4, half-maximal inhibitory concentration: 2500 nM
Compound 4: middle estimate off by 6.0-fold (0.78 log units), on the high side; the measured number lies below the stated range.
By their numbers in this assay, from the lowest: compound 4; then compounds 2, 1 and 3 (each within the scatter of the next, the first and the last beyond it).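

The amide nitrogen is now shown to be a position where a change of substituent can move the number in this assay beyond the scatter: a 6.1-fold lower number from compound 3 to compound 4 (0.78 log units; beyond the scatter). A ring on this nitrogen is therefore not required for the stronger inhibition seen with compound 4, whose 1-(tert-butoxycarbonyl)ethyl group has no ring, 2 hydrogen-bond acceptors and 1 defined stereocentre. No supporting data bear on what lies behind this step.

Going by these compounds alone, the single step changes all of these features at once, so the share of each remains unresolved. Open questions are whether a carboxylic acid in place of the tert-butyl ester, a plain ethyl chain or the opposite configuration at the stereocentre would keep the number of compound 4 at this nitrogen.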